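A few compounds are considered here, and "the series" means these few. Any claim that something is new, unique, unknown or untested is made for them only; others in the source may bear on it.

Working notes on the series.

Compound 1 is `CCCc1c(OC)nc2nc(C(=O)c3ccccc3)cn2c1CC`. In a functional assay on the whole organism with Rattus norvegicus as the target (a lower number here means that less compound is needed, a higher number that more compound is needed for the effect), compound 1 gives 10 mg/kg. Compound 2, `CCCCc1c(OC)nc2nc(C(=O)c3ccccc3)cn2c1CC`, gives 10 mg/kg in the same assay, and compound 3, `C=CCc1c(OC)nc2nc(C(=O)c3ccccc3)cn2c1CC`, gives 10 mg/kg. The three measured steps are all on the saturated chain: no change at the digits printed from compound 1 to compound 2 (within the scatter), no change at the digits printed from compound 1 to compound 3 (within the scatter) and no change at the digits printed from compound 2 to compound 3 (within the scatter). Within the data shown here, compound 1 therefore stands level with compounds 2 and 3 on the numbers so far, and none of the chain changes moves the minimum effective dose beyond the scatter.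

The next compound, compound 4, is `CCCc1c(SC)nc2nc(C(=O)c3ccccc3)cn2c1CC`. It differs from compound 1 in one place: methylsulfanyl in place of methoxy on an aromatic carbon. The methoxy leaves and methylsulfanyl enters on the aromatic carbon of the six-membered ring of the shared core; the heavy-atom count and the acceptor count are unchanged.

Among the measured compounds shown here, no measured step touches this position, so nothing speaks directly to the exchange. For the measured compounds named here, the only guidance is the flat behaviour of the series under the chain changes, which suggests that single small exchanges have not so far shifted the read-out. The expectation is therefore a step of no change at the digits printed from compound 1 to compound 4 (within the scatter), that is, no change beyond the scatter. Compound 4 is estimated at 10 mg/kg, with a range from 3 mg/kg to 30 mg/kg.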

Compound 4, minimum effective dose: 10 mg/kg
Compound 4: the middle estimate sits on the measured number at the digits printed; measured number inside the range.
By their numbers in this assay, from the lowest: compounds 1, 2, 3 and 4 (each within the scatter of the next).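

In this assay, the exchange on the aromatic carbon next to the ring nitrogen gives no change at the digits printed from compound 1 to compound 4 (within the scatter), and this is the only step shown that leaves the saturated chain. Compounds 1, 2 and 3 all carry methoxy here, so they said nothing about this position; the new step shows that, with the propyl group and the ethyl group held constant, methylsulfanyl can stand in place of methoxy without a shift in the minimum effective dose beyond the scatter. The two groups have the same counts of heavy atoms and hydrogen-bond acceptors, and nothing in the data shown accounts for the level read-out.

What stays open is how far this position tolerates a larger departure, since only methoxy and methylsulfanyl appear on this carbon, and an amine, a hydroxyl group or a longer chain such as butoxy has no value among the compounds shown. The ethyl group also stays the same in all four compounds, so the series shown gives no reading of a change at that place.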